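A few compounds are considered here, and "the series" means these few. Any claim that something is new, unique, unknown or untested is made for them only; others in the source may bear on it.

Among the compounds with values here, compound 2 `COc1c(NS(=O)(=O)c2ccc(F)cc2)cc(-c2ccc3nc(NC(=O)C4CC4)nn3c2)cc1C(N)=O` is the one compound with a numbered reading: in a functional assay on HCT-116 cells (Homo sapiens) for antiproliferative activity, read by MTT assay, with a stated time of 72 h (on this read-out higher numbers stand for weaker inhibition and lower numbers for stronger inhibition), compound 2 gives 43500 nM. Compound 1 `NC(=O)c1cc(NS(=O)(=O)c2ccc(F)cc2)cc(-c2ccc3nc(NC(=O)C4CC4)sc3c2)c1` reaches only a limit of this assay, giving > 50000 nM rather than a number, and the limit of > 50000 nM in this assay, at which 1 of the 2 values shown sits, marks that ceiling. Compound 3 `COc1c(NS(=O)(=O)c2ccc(F)cc2)cc(-c2ccc3nc(NC(C)=O)nn3c2)cc1C(N)=O` differs from compound 2 by methyl in place of cyclopropyl on a carbonyl carbon, with the cyclopropylcarbonyl becoming acetyl. Within the data shown here, no measured pair shows this change, so the step from compound 2 to compound 3 is expected to stay within the scatter, a 1.1-fold higher number from compound 2 to compound 3 (0.06 log units; within the scatter), and compound 3 is estimated at 50000 nM (range 18000 nM to 140000 nM).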

Compound 3, half-maximal inhibitory concentration: 25400 nM
For compound 3 the middle estimate is 2.0-fold (0.29 log units) above the measured one; the range from low to high includes it.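

In this assay, methyl in place of cyclopropyl on a carbonyl carbon gives a 1.7-fold lower number from compound 2 to compound 3 (0.23 log units; within the scatter). Within the data shown here, this is the first reading of this change, and it shows that cyclopropylcarbonyl can become acetyl at this position without a difference that stands clear of the scatter. Nothing measured here bears on the reason for this result. On these data alone, whether a longer chain, a phenyl ring or an aminomethyl group on this carbonyl carbon would give a step beyond the scatter stays open, as does the effect of the same change on the core of compound 1.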